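Nitrophenyl position in a cyclohexanone dienone series

The source may hold more compounds than are shown below. What is called first, only, known or untested is meant among the compounds shown, and "the series" means these compounds.

Measured so far:
compound 1, `CN(C)c1ccc(/C=C2\CCC/C(=C\c3cccc([N+](=O)[O-])c3)C2=O)cc1`, 30000 nM
compound 2, `COc1cc(/C=C2\CCC/C(=C\c3cccc([N+](=O)[O-])c3)C2=O)cc(OC)c1OC`, 59000 nM
compound 3, `CN(C)c1ccc(/C=C2\CCC/C(=C\c3ccc([N+](=O)[O-])cc3)C2=O)cc1`, > 400000 nM (a limit)

All numbers come from a functional assay on HL-60 cells (Homo sapiens) for cytotoxicity, with a stated time of 24 h; a lower number here means that less compound is tolerated, a higher number that more compound is tolerated. Compound 1 gives 30000 nM, and compound 2 gives 59000 nM; the two sit within the scatter of each other, so no order between them is read. For compound 3 this assay reports only a limit, > 400000 nM. The difference between the core of compound 1 and the core of compound 2 is not broken down here.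

Compound 3 differs from compound 1 by 4-nitrophenyl in place of 3-nitrophenyl on a double-bonded chain carbon bound to a double-bonded ring carbon. This change gave an at least 13-fold higher number from compound 1 to compound 3 (1.12 log units; beyond the scatter); the step is open-ended because of the limit of > 400000 nM in this assay, at which 1 of the 3 values shown sits.

Compound 4, `COc1cc(/C=C2\CCC/C(=C\c3ccc([N+](=O)[O-])cc3)C2=O)cc(OC)c1OC`, is not yet measured. It differs from compound 2 by 4-nitrophenyl in place of 3-nitrophenyl on a double-bonded chain carbon bound to a double-bonded ring carbon, the same change that separates compound 3 from compound 1, at the same place. The expectation for compound 4 in this assay rests on compound 2 and its value 59000 nM and on the step from compound 1 to compound 3, an at least 13-fold higher number from compound 1 to compound 3 (1.12 log units; beyond the scatter): a step of similar size, an 8.5-fold higher number from compound 2 to compound 4 (0.93 log units; beyond the scatter), is expected from compound 2 to compound 4. Since compound 2 already sits at the higher of the two numbers seen, compound 4 is expected to reach or pass the limit of this assay, so that a limit rather than a number is the likeliest outcome. The estimate for compound 4 is 500000 nM, in the range 150000 nM to 1500000 nM. Only two examples of this change exist among the compounds shown, so the expectation is weakly founded.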

Compound 4, half-maximal cytotoxic concentration: 1100 nM
Beside the measured number, compound 4's estimate is 450-fold (2.66 log units) above it, outside the stated range (below it).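

In this assay, 4-nitrophenyl in place of 3-nitrophenyl on the core of compound 2 gave a 54-fold lower number from compound 2 to compound 4 (1.73 log units; beyond the scatter), so this change cannot be carried from one core to the other in this series, in either direction or size: the same change on two cores in this assay, an at least 13-fold higher number (1.12 log units; beyond the scatter) from compound 1 to compound 3 and a 54-fold lower number (1.73 log units; beyond the scatter) from compound 2 to compound 4, at least 710-fold (2.85 log units) apart, beyond the scatter of two such steps

The two pairs show that the outcome of this one change depends on the core it sits on, but they do not show which feature of the two cores decides it, and they do not fix the full size of the step on the core of compound 1: the limit of > 400000 nM in this assay, at which 1 of the 4 values shown sits.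

Among the compounds shown here, with only two cores, it also remains unsettled which of the two results is the more usual one for this change, and compound 4, at 1100 nM, has no counterpart on another core to confirm it. Open as well is how a nitrile or a carboxylic acid in place of the nitro group would behave on each of these cores, and whether the same dependence on the core would then appear.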